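The compounds below may be only part of what the source reports. "The series", "measured", "known", "first", "only" and "open" are said of these compounds alone.

Measured so far in a functional assay on HGC-27 cells (Homo sapiens) for inhibition, read by MTT assay, with a stated time of 72 h; a lower number here means a stronger inhibitor, a higher number a weaker inhibitor:
compound 1 `Cc1cc(N2CC[C@@H](C)[C@@H](N(C)c3ncnc4[nH]ccc34)C2)n2nc(SCc3nc4ccccc4[nH]3)nc2n1`: > 100000 nM, a limit and not a number
compound 2 `Cc1cc(N2CC[C@@H](C)[C@@H](N(C)c3ncnc4[nH]ccc34)C2)n2nc(SCc3csc4ccc(Cl)cc34)nc2n1`: > 100000 nM, a limit and not a number
compound 3 `Cc1cc(N2CC[C@@H](C)[C@@H](N(C)c3ncnc4[nH]ccc34)C2)n2nc(SCCc3ccccc3)nc2n1`: 11800 nM

Compound 3 is the only one of the three with a true number, and the other two sit at one limit: the limit of > 100000 nM in this assay, at which 2 of the 3 values shown sit. The next step leads to compound 4 `C=CCSc1nc2nc(C)cc(N3CC[C@@H](C)[C@@H](N(C)c4ncnc5[nH]ccc45)C3)n2n1`, with vinyl in place of benzyl on a saturated chain carbon bound to a sulfur, or phenethylsulfanyl to allylsulfanyl: vinyl in place of benzyl on a saturated chain carbon bound to a sulfur.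

Two measured steps change the same place: an at least 8.4-fold lower number from compound 1 to compound 3 (0.92 log units; beyond the scatter) and an at least 8.4-fold lower number from compound 2 to compound 3 (0.92 log units; beyond the scatter). Both are beyond the scatter, but their true size is open. a step that the two limits leave unreadable from compound 1 to compound 2 adds nothing. All three measured groups carry aromatic rings, while the entering group has none, so these steps give only a loose guide. The expectation therefore starts from compound 3 at 11800 nM in this assay. The estimated change is a 1.5-fold higher number from compound 3 to compound 4 (0.18 log units; within the scatter), so no clear step beyond the scatter is expected, with a slight lean towards a higher number. For compound 4 the expected value is 18000 nM, with an estimated range of 5000 nM to 80000 nM.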

Compound 4, half-maximal inhibitory concentration: 35200 nM
Estimate against measurement, compound 4: 2.0-fold (0.29 log units) below, within the range that was stated.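

In this assay, within the data shown here, the change from phenethylsulfanyl to allylsulfanyl gives the first step at this place with a true number at both ends, a 3.0-fold higher number from compound 3 to compound 4 (0.47 log units; beyond the scatter), so the loss of the benzyl ring weakens the compound but still leaves a measurable value. The group without a ring also reads better than both fused-ring groups, with an at least 2.8-fold lower number from compound 2 to compound 4 (0.45 log units; beyond the scatter) and an at least 2.8-fold lower number from compound 1 to compound 4 (0.45 log units; beyond the scatter), so an aromatic ring on the chain is not enough for a measurable value here, and compound 3 alone among the ring-bearing compounds has one. Both of these steps give only a minimum size, since compound 1 and compound 2 carry limits and not numbers: the limit of > 100000 nM in this assay, at which 2 of the 4 values shown sit.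

From the compounds shown here alone, whether the gain of benzyl over vinyl lies in the aromatic ring or simply in the longer group stays open, and cyclohexyl on the same chain would separate the two. Going by these compounds, how a chain ending in an amine or a carboxylic acid would read at this place is also open.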